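A few compounds are considered here, and "the series" means these few. Any claim that something is new, unique, unknown or untested is made for them only; others in the source may bear on it.

Measured so far in an assay on isolated protein for inhibition of P-selectin glycoprotein ligand 1 (Homo sapiens), read by surface plasmon resonance, tested at 250 uM; a lower number here means less inhibition, a higher number more inhibition at the concentration tested (going by the name of the read-out):
compound 1, `COc1ccc(C2(c3nc4c(C(F)(F)F)cccc4c(C(=O)O)c3O)CC2)cc1`: 26%
compound 2, `O=C(O)c1c(O)c(C2(c3cccs3)CC2)nc2c(C(F)(F)F)cccc12`: 15%

Among the compounds with values here, compound 2 gives the lower of the two numbers; the nearest is compound 1, and the one measured step, a number 11 percentage points lower from compound 1 to compound 2 (beyond the scatter), is a modest fall that lies beyond the scatter.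

Compound 3, `O=C(O)c1c(O)c(C2(c3ccsc3)CC2)nc2c(C(F)(F)F)cccc12`, has the same atoms as compound 2 joined differently: thiophen-3-yl in place of thiophen-2-yl on a saturated ring carbon. The change sits on the saturated ring carbon of the three-membered ring.

Within the data shown here, no measured step covers this change. Among the measured compounds shown here, the only step on record, a number 11 percentage points lower from compound 1 to compound 2 (beyond the scatter), exchanges a 4-methoxyphenyl for a thiophen-2-yl on that same carbon and is of a different kind, so it says little about moving from thiophen-2-yl to thiophen-3-yl. With nothing closer to go on, the expectation for this assay is a step of no clear direction, most likely within the scatter, so no change at the digits printed from compound 2 to compound 3 (within the scatter) is the estimated shift.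

Compound 3 is therefore estimated at 15% in this assay, with a range from 3% to 30%.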

Compound 3, a percentage reported as inhibition, at one concentration (the size of the read-out at that concentration, not a potency): 7%
For compound 3 the middle estimate is 8 percentage points above the measured one, within the range that was stated.
By their numbers in this assay, from the lowest: compounds 3 and 2 (each within the scatter of the next); then compound 1.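

Exchanging thiophen-2-yl for thiophen-3-yl on the saturated ring carbon gives a number 8 percentage points lower from compound 2 to compound 3 (within the scatter) in this assay, so the attachment point of the thiophene on the three-membered ring makes no difference that this read-out can resolve. Thiophen-3-yl in place of 4-methoxyphenyl gives a number 19 percentage points lower from compound 1 to compound 3 (beyond the scatter) and, read with a number 11 percentage points lower from compound 1 to compound 2 (beyond the scatter) from the earlier pair, this places compound 1 above both thiophene compounds, making the separation one between 4-methoxyphenyl and thiophene rather than one tied to a single thiophene isomer. Nothing at hand accounts for the values at this position.

The compounds shown leave open whether an unsubstituted phenyl on that carbon would group with compound 1 or with the thiophene compounds, so the contribution of the methoxy group cannot be separated from that of the six-membered aromatic ring. Also open, from the compounds shown here alone, is how the numbers in this assay would respond to a change outside this position, such as a methyl ester in place of the carboxylic acid on the shared core.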